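The source may hold more compounds than are shown below. What is called first, only, known or untested is meant among the compounds shown, and "the series" means these compounds.

Working notes on the series. In a functional assay on U-87MG ATCC cells (Homo sapiens) for inhibition, read by MTT assay, with a stated time of 72 h (a lower number here means a stronger inhibitor, a higher number a weaker inhibitor), compound 2 `COc1cc2c(Oc3ccc(NC(=O)c4nn(-c5ccccc5C(F)(F)F)c(=O)cc4C)cc3F)ccnc2cc1OCCCN1CCC(C)CC1` gives 1120 nM. Compound 1 `COc1cc2c(Oc3ccc(NC(=O)c4nn(-c5ccccc5C(F)(F)F)c(=O)cc4C)cc3F)ccnc2cc1OCCCN1CCCCC1` gives 1150 nM and compound 3 `COc1cc2c(Oc3ccc(NC(=O)c4nn(-c5ccccc5C(F)(F)F)c(=O)cc4C)cc3F)ccnc2cc1OCCCN1CCN(C)CC1` gives 1170 nM; the three numbers lie within the scatter of one another, so compound 2 is not separated from either of them. The change to compound 4 `COc1cc2c(Oc3ccc(NC(=O)c4nn(-c5cccc(F)c5)c(=O)cc4C)cc3F)ccnc2cc1OCCCN1CCC(C)CC1` is 3-fluorophenyl in place of 2-(trifluoromethyl)phenyl on an aromatic nitrogen. Going by the values given here, no measured step touches that position: a 1.0-fold lower number from compound 1 to compound 2 (0.01 log units; within the scatter), a 1.0-fold higher number from compound 1 to compound 3 (0.01 log units; within the scatter) and a 1.0-fold higher number from compound 2 to compound 3 (0.02 log units; within the scatter) each vary only the saturated ring at the end of the chain, and each falls within the scatter. Those steps show that the number holds steady across such changes, but they carry no information about the aryl group on the aromatic nitrogen. Going by these compounds, with nothing bearing on the change, the step is expected to be a 1.0-fold lower number from compound 2 to compound 4 (0.01 log units; within the scatter), with no direction claimed beyond the scatter, and the range is widened because the position is untested in this set. Compound 4 is estimated at 1100 nM, expected to fall between 350 nM and 3500 nM.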

Compound 4, half-maximal inhibitory concentration: 1800 nM
The estimate for compound 4 lay 1.6-fold (0.21 log units) below the measured number; low and high end bracket the measured number.
By their numbers in this assay, from the lowest: compounds 2, 1, 3 and 4 (each within the scatter of the next).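

In this assay, going by these compounds alone, the first measured change to the aryl group on the aromatic nitrogen is a 1.6-fold higher number from compound 2 to compound 4 (0.21 log units; within the scatter), and this step lies within the scatter. Within the data shown here, the exchange of 2-(trifluoromethyl)phenyl, 10 heavy atoms, for 3-fluorophenyl, 7 heavy atoms, therefore does not separate the two compounds, so this position, untested by the earlier steps, shows no resolved shift for this one pair. Nothing available explains the size of this step.

Among these compounds, it remains open whether the number would also hold with an unsubstituted phenyl or a cyclohexyl group on this nitrogen, since only two aryl groups appear here. Going by these compounds, it is also open whether the piperidin-1-yl and 4-methylpiperazin-1-yl chain ends would stay within the scatter of compound 4 alongside 3-fluorophenyl.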